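Configuration switch in a urea series: compound 2 to compound 3

The source may hold more compounds than are shown below. What is called first, only, known or untested is meant among the compounds shown, and "the series" means these compounds.

Measured so far in an ADME assay on the whole organism with Oryza sativa as the target, tested at 10 uM; a lower number here means a stronger effect, a higher number a weaker effect of the compound at the concentration tested:
compound 1 `C[C@H](NC(=O)Nc1ccccc1C(F)(F)F)c1ccccc1`: 97%
compound 2 `C[C@@H](NC(=O)Nc1ccccc1F)c1ccccc1`: 77%

Compound 2 holds the lowest of the two numbers; its nearest neighbour is compound 1, whose number stands higher by a gap beyond the usual scatter. Among the measured compounds shown here, no pair of measured compounds differs in one place only, so no step has been measured yet.

Compound 3 `C[C@H](NC(=O)Nc1ccccc1F)c1ccccc1` is not yet measured. It relates to compound 2 as follows: the two compounds have the same atoms and bonds and differ only in configuration as drawn: 1 of 1 stereo elements differ; a stereocentre at a saturated chain carbon is drawn R in compound 2 and S in compound 3. Only the stereocentre at the saturated chain carbon is changed, from R to S as drawn.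

For the measured compounds named here, with no measured step to lean on, the expectation for the step from compound 2 to compound 3 rests on compound 1, which carries the S drawing and gives 97% in this assay; a modest rise is expected, a number 9 percentage points higher from compound 2 to compound 3 (within the scatter), though a step within the scatter is also plausible. Compound 3 is accordingly estimated at 86%, between 68% and 100%.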

Compound 3, a percentage reported as activity, at one concentration (the size of the read-out at that concentration, not a potency): 65%
The estimate for compound 3 lay 21 percentage points above the measured number, outside the stated range (below it).
By their numbers in this assay, from the lowest: compound 3; then compound 2; then compound 1.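

In this assay, configuration alone matters at the saturated chain carbon: going from R to S as drawn gives a number 12 percentage points lower from compound 2 to compound 3 (beyond the scatter). This step can be assigned to that stereocentre because nothing else changes: the fact that compounds 2 and 3 differ only in the configuration as drawn. With the S drawing held, fluoro in place of trifluoromethyl on an aromatic carbon gives a number 32 percentage points lower from compound 1 to compound 3 (beyond the scatter), so within these two pairs the aromatic substituent step is the larger one.

Whether the S drawing also gives the lower number with trifluoromethyl remains open; the only configuration pair shown carries fluoro. Also open, going by these compounds, is how a methoxy group, an amine or a carboxylic acid on that aromatic carbon would compare with fluoro in this assay.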